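The source may report more compounds than this note shows. Statements on the series, on what has been measured and on what is new or still open speak of the compounds shown alone.

Three compounds share one core and differ only in the group attached to the carbonyl carbon of the amide. Compound 1 `COc1cccc(C(=O)Nc2cc(-c3ccccc3)nn2-c2ccccc2)c1` gives 102 nM in a functional assay on cells for positive allosteric modulation of metabotropic glutamate receptor 5 (Rattus norvegicus), read by calcium flux; on this read-out higher numbers stand for an effect only at larger amounts of compound and lower numbers for an effect already at smaller amounts. Compound 2 `O=C(Nc1cc(-c2ccccc2)nn1-c1ccccc1)c1ccc(Cl)c(Cl)c1` gives 13 nM, and the step of a 7.8-fold lower number from compound 1 to compound 2 (0.89 log units; beyond the scatter) is beyond the scatter. Compound 3 `Cc1ccc(C(=O)Nc2cc(-c3ccccc3)nn2-c2ccccc2)cn1` gives 280 nM, the highest of the three numbers: the step of a 2.7-fold higher number from compound 1 to compound 3 (0.44 log units; beyond the scatter) and the step of a 22-fold higher number from compound 2 to compound 3 (1.33 log units; beyond the scatter) both run upward, so compound 3 needs the largest amount of the three to act.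

Compound 4 `O=C(Nc1cc(-c2ccccc2)nn1-c1ccccc1)C1CCCC1` takes the next step, (cyclopentyl in place of 6-methylpyridin-3-yl on a carbonyl carbon). Within the data shown here, no measured pair shows a saturated ring entering at this place; the measured steps only show that the two aromatic carbon rings gave lower numbers than the methylpyridinyl group of compound 3. Since every change at the carbonyl carbon so far has moved the number beyond the scatter, compound 4 is expected to shift as well, most likely toward a modestly lower number, though a flat outcome cannot be ruled out. Compound 4 is therefore estimated at 120 nM, within 30 nM to 500 nM, a step of a 2.3-fold lower number from compound 3 to compound 4 (0.37 log units; beyond the scatter).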

Compound 4, half-maximal effective concentration: 3410 nM
Compound 4: middle estimate off by 28-fold (1.45 log units), on the low side; measured number above the stated range.
By their numbers in this assay, from the lowest: compound 2; then compound 1; then compound 3; then compound 4.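

In this assay the cyclopentyl group is the only non-aromatic ring on the carbonyl carbon among these compounds, and it produces a 12-fold higher number from compound 3 to compound 4 (1.09 log units; beyond the scatter) as well as a 33-fold higher number from compound 1 to compound 4 (1.52 log units; beyond the scatter) and a 260-fold higher number from compound 2 to compound 4 (2.42 log units; beyond the scatter) in the comparisons with the other two. All three aromatic rings at this place therefore give lower numbers than this saturated ring of carbon only, with no compound shown going against that, so the range at this single position is much wider than the first three compounds suggested. Nothing measured here says why the number rises so far with this change.

With one saturated ring in hand, the loss of the aromatic ring cannot be separated from the change in ring size. A cyclohexyl ring, a butyl chain or a piperidine ring on the same carbonyl carbon could help to tell these apart.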